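Benzylamino in place of trifluoromethoxyphenylamino on the amine nitrogen

This account rests on a few compounds, and the source may have more. Where it says the series, first, only, none or still open, it means among the compounds named here.

Compound 3 `O=C(C1=C(Nc2ccc(OC(F)(F)F)cc2)C(=O)N(CCCn2ccnc2)C1c1ccc(Br)cc1)c1ccccc1` gives the lowest of the three numbers measured in a functional assay on U2OS cells (Homo sapiens) for antiproliferative activity, read by MTT assay, with a stated time of 72 h (a lower number here means a stronger inhibitor, a higher number a weaker inhibitor), at 11500 nM. Compound 1 `CCCCOC1=C(C(=O)c2ccccc2)C(c2ccc(Br)cc2)N(CCCn2ccnc2)C1=O` gives 32400 nM and compound 2 `CCOc1ccc(NC2=C(C(=O)c3ccccc3)C(c3ccc(Br)cc3)N(CCCn3ccnc3)C2=O)cc1` gives 26200 nM in this assay. The steps of a 2.8-fold lower number from compound 1 to compound 3 (0.45 log units; beyond the scatter) and a 2.3-fold lower number from compound 2 to compound 3 (0.36 log units; beyond the scatter) are modest, while a 1.2-fold lower number from compound 1 to compound 2 (0.09 log units; within the scatter) stays within the scatter. Compound 4 `O=C(C1=C(NCc2ccccc2)C(=O)N(CCCn2ccnc2)C1c1ccc(Br)cc1)c1ccccc1` carries benzyl in place of 4-(trifluoromethoxy)phenyl on an amine nitrogen. Among the compounds with values here, no measured step swaps an aryl for a benzyl on this nitrogen; the nearest guide is a 2.3-fold lower number from compound 2 to compound 3 (0.36 log units; beyond the scatter), where removing the trifluoromethyl cost a modest step, and compound 1, with butoxy in place of the arylamino, runs weaker. A modest rise, a 1.9-fold higher number from compound 3 to compound 4 (0.28 log units; within the scatter), is therefore expected in this assay. Compound 4 is expected to give 22000 nM, within 9000 nM to 55000 nM.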

Compound 4, half-maximal inhibitory concentration: 32500 nM
The estimate for compound 4 lay 1.5-fold (0.17 log units) below the measured number, and the stated range covers the measured number.
By their numbers in this assay, from the lowest: compound 3; then compounds 2, 1 and 4 (each within the scatter of the next).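

At the amine nitrogen in this assay, benzyl in place of 4-(trifluoromethoxy)phenyl gives a 2.8-fold higher number from compound 3 to compound 4 (0.45 log units; beyond the scatter) and so loses what that aryl group gained. Benzyl in place of 4-ethoxyphenyl gives a 1.2-fold higher number from compound 2 to compound 4 (0.09 log units; within the scatter) and benzylamino in place of butoxy gives a 1.0-fold higher number from compound 1 to compound 4 (0.00 log units; within the scatter) so that both steps stay within the scatter. Among these four, only compound 3 stands apart from the others. Still open, going by these compounds, is whether a longer chain than benzyl or a carboxylic acid on the phenyl ring would take the number below that of compound 3. No measurement at hand accounts for these differences.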